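From a Trifluoromethyl Oxime to a Carbamate-Capped Oxime

A few compounds are considered here, and "the series" means these few. Any claim that something is new, unique, unknown or untested is made for them only; others in the source may bear on it.

Of the compounds shown here, three have been measured in a functional assay (blood) for inhibition, with Homo sapiens as the target; a lower number here means a stronger inhibitor, a higher number a weaker inhibitor. Compound 1 `CO[C@]1(c2cc(F)cc(Sc3ccc(/C(C)=N/O)cc3)c2)CCO[C@@H](C)C1` gives 40 nM, compound 2 `COC1(c2csc(Sc3ccc4c(c3)CC/C4=N\O)c2)CCOCC1` gives 130 nM, and compound 3 `O/N=C(/c1ccc(Sc2cc(F)cc(C3CCOCC3)c2)cc1)C(F)(F)F` gives 280 nM. Compound 3 thus stands at the highest number of the three; its nearest neighbour is compound 2, and the gap to compound 1 is larger still, both gaps lying beyond the usual scatter. No pair among these three differs in only one place, so no single-point step is available as a guide.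

Compound 4 `C/C(=N\OC(=O)N(C)C)c1ccc(Sc2cc(F)cc(C3CCOCC3)c2)cc1` differs from compound 3 in one place: a group of 9 heavy atoms (5 carbon, 2 nitrogen, 2 oxygen; no ring) in place of a group of 7 heavy atoms (2 carbon, 1 nitrogen, 1 oxygen, 3 fluorine; no ring), on an aromatic carbon. The group that leaves carries the one hydrogen-bond donor; the group that enters carries none and one more acceptor. Compound 1, with the lowest number, rests on a different core and offers only a loose hint. The step is expected to be modest and toward a somewhat lower number, though a result within the scatter would not surprise. Compound 4 is therefore expected to give about 150 nM, with a range from 40 nM to 600 nM. That estimate means a step of a 1.9-fold lower number from compound 3 to compound 4 (0.27 log units; within the scatter) in this assay.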

Compound 4, half-maximal inhibitory concentration: 2610 nM
The estimate for compound 4 lay 17-fold (1.24 log units) below the measured number, outside the stated range (above it).
By their numbers in this assay, from the lowest: compound 1; then compound 2; then compound 3; then compound 4.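

In this assay, the exchange on this aromatic carbon, para to a large group, gives a 9.3-fold higher number from compound 3 to compound 4 (0.97 log units; beyond the scatter). Going by these compounds alone, this is the first step between compounds that differ in one place, and it shows that the number responds to the group at this position: the group with 9 heavy atoms and 0 hydrogen-bond donors goes with a weaker inhibitor than the trifluoromethyl oxime with 1 hydrogen-bond donor. No measurement bearing on the reason for this step is available.

The step replaces the trifluoromethyl and caps the oxime oxygen at once, so the compounds shown do not tell these two changes apart. Nor do they show how this shared core would respond to an O-methyl oxime, a primary amide or a carboxylic acid at this position.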